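The source may report more compounds than this note shows. Statements on the series, on what has been measured and on what is new or still open speak of the compounds shown alone.

Measured compounds in a functional assay on A-375 cells (Homo sapiens) for cytotoxicity, read by MTT assay, with a stated time of 72 h, tested at 3 uM; a higher number here means more inhibition of growth at the concentration tested, a lower number less inhibition of growth:

Compound 1 `N/C(=N\NC(=S)N1CCCCCC1)c1ccccn1` gives 78.6%.
Compound 2 `Cc1ccnc(/C(N)=N/NC(=S)N2CCSCC2)c1` gives 67.2%.
Compound 3 `N/C(=N\NC(=S)N1CCSCC1)c1ccccn1` gives 80%.

Compound 1 and compound 3 differ in the ring attached to the thiocarbonyl; the difference between the two cores is not broken down here. Their numbers in this assay lie within the scatter of each other, so no order between them is drawn. Compound 2 stands below compound 1 by a gap beyond the scatter.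

One counted change is seen in the series. From compound 3 to compound 2 it is methyl in place of hydrogen on an aromatic carbon, and in this assay it gives a number 12.8 percentage points lower from compound 3 to compound 2 (beyond the scatter). The unmeasured compound 4 `Cc1ccnc(/C(N)=N/NC(=S)N2CCCCCC2)c1` arises from compound 1 by methyl in place of hydrogen on an aromatic carbon, which is the same change, at the same place, on the other core.

Among the compounds with values here, the expectation for compound 4 in this assay rests on the single measured instance of this change: because a number 12.8 percentage points lower from compound 3 to compound 2 (beyond the scatter) lowered the number by a modest amount on the core of compound 3, a step of similar size is expected on the core of compound 1, giving a number 12.6 percentage points lower from compound 1 to compound 4 (beyond the scatter). With one example only, the size is uncertain, and a result anywhere from little change to a somewhat larger drop would not be surprising. Compound 4 is therefore estimated at 66%, with the expected range from 52% to 79%.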

Compound 4, percent growth inhibition at one concentration: 70%
Estimate against measurement, compound 4: 4 percentage points below, and the stated range covers the measured number.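

In this assay, methyl in place of hydrogen on an aromatic carbon, opposite the ring nitrogen, now appears on two cores, and the new step reads a number 8.6 percentage points lower from compound 1 to compound 4 (within the scatter). Set beside the earlier step, the size of the change does not differ measurably between the two cores: the same change on two cores in this assay, a number 12.8 percentage points lower (beyond the scatter) from compound 3 to compound 2 and a number 8.6 percentage points lower (within the scatter) from compound 1 to compound 4, 4.2 percentage points apart, within the scatter of two such steps

The series therefore gives no sign that the core of compound 1 and the core of compound 3 respond differently to this change, but the new step alone does not establish a real effect of the methyl on the core of compound 1, and two pairs tested at a single concentration give no general rule for other cores.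

The compounds shown carry only hydrogen or methyl at this place, which leaves open how a longer chain, an amine or a carboxylic acid there would read in this assay. Also open, going by these compounds, is whether the methyl step would hold at other places on the aromatic ring, or on a core with an open-chain dialkylamine attached to the thiocarbonyl.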